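This account rests on a few compounds, and the source may have more. Where it says the series, first, only, none or still open, it means among the compounds named here.

In a physicochemical assay for solubility, in phosphate buffer, at pH 6.5 (a lower number here means a less soluble compound, a higher number a more soluble compound), compound 2 `CCOc1cc(CN2CCC(NC(=O)c3ccc(N)nc3)CC2)cc(OCc2ccccc2)c1-c1ccc(F)cc1` gives 5 ug/mL, the lowest of the three numbers measured. Compound 4 `CCOc1cc(CN2CCC(NC(=O)c3ccc(N)nc3)CC2)cc(OCC)c1-c1ccc(F)cc1` differs from it by methyl in place of phenyl on a saturated chain carbon bound to an oxygen on an aromatic ring, or benzyloxy to ethoxy. Within the data shown here, no measured step makes this change. The only one, a 1.3-fold higher number from compound 1 to compound 3 (0.13 log units; within the scatter), sits on a carbonyl carbon and does not touch this place. Compound 1 `CCOc1cc(CN2CCC(NC(=O)c3ccc(NC)nc3)CC2)cc(OCC)c1F` at 330 ug/mL and compound 3 `CCOc1cc(CN2CCC(NC(=O)c3cncc(C)c3)CC2)cc(OCC)c1F` at 443 ug/mL carry ethoxy there but also differ from compound 4 elsewhere, so only part of their gap is expected to carry over. The expected step, beyond the scatter, is a 6.0-fold higher number from compound 2 to compound 4 (0.78 log units; beyond the scatter). Compound 4 is estimated at 30 ug/mL, within an expected range of 10 ug/mL to 100 ug/mL.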

Compound 4, solubility: 123 ug/mL
Compound 4: middle estimate off by 4.1-fold (0.61 log units), on the low side, outside the stated range (above it).
By their numbers in this assay, from the lowest: compound 2; then compound 4; then compounds 1 and 3 (each within the scatter of the next).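

In this assay, among these compounds, replacing benzyloxy with ethoxy on the core of compound 2 gives a 25-fold higher number from compound 2 to compound 4 (1.39 log units; beyond the scatter), the only step that touches this position. It shows that this position alone can move the read-out by a large amount, with phenyl leaving, methyl entering and no change in the counted hydrogen-bond donors, hydrogen-bond acceptors or net charge. No available evidence bears on the size of this step. This single pair leaves open whether the step would hold with a different amide group. It also leaves open how a longer chain, an amine or a carboxylic acid at this position would read.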